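This account rests on a few compounds, and the source may have more. Where it says the series, first, only, none or still open, it means among the compounds named here.

Measured so far:
Compound 2, `CC(C)(C)c1ccc(/C=C/C(=O)c2ccc(OCC(=O)N[C@H]3CCOC3=O)cc2)cc1`: 17200 nM in a functional assay on MGC-803 cells (Homo sapiens) for antiproliferative activity, read by MTT assay, with a stated time of 72 h; a lower number here means a stronger inhibitor, a higher number a weaker inhibitor.
Compound 1, `CCOc1ccccc1OCCSC(=S)N[C@H]1CCOC1=O`: > 64000 nM, a limit of the assay.
Compound 3, `Cc1cc(Cl)ccc1NCC(=O)N[C@H]1CCOC1=O`: > 64000 nM, also a limit of the assay.

Compound 2 is the only one of the three that gives a number in this assay; the other two sit at the limit of > 64000 nM in this assay, at which 2 of the 3 values shown sit. Compound 4, `O=C(COc1ccc(C(=O)/C=C/c2ccccc2)cc1)N[C@H]1CCOC1=O`, is the next compound to be measured. It differs from compound 2 in one place: hydrogen in place of tert-butyl on an aromatic carbon. Among the compounds with values here, no measured pair here shows what such a change does in this assay, so no size of step can be read from the data. The expected step is small, a 1.5-fold higher number from compound 2 to compound 4 (0.16 log units; within the scatter), toward a weaker inhibitor at most. Compound 4 is therefore expected to give about 25000 nM, in the range 9000 nM to 64000 nM.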

Compound 4, half-maximal inhibitory concentration: > 64000 nM
Compound 4: a limit, no number; the forecaster's own chance of this, stated with the estimate: 25%; at least 2.5-fold (0.40 log units) between middle value and limit.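

Going from 4-(tert-butyl)phenyl to phenyl gives an at least 3.7-fold higher number from compound 2 to compound 4 (0.57 log units; beyond the scatter) in this assay and is the first step that can be read at this place, on an aromatic carbon para to a large group. In this pair, losing the tert-butyl group costs activity beyond the scatter. Compound 4 gives > 64000 nM as a limit of the assay, not a number, so only a floor for the step is known, and it joins the other compounds at that limit: the limit of > 64000 nM in this assay, at which 3 of the 4 values shown sit.

From the compounds shown here alone, it stays open whether a methyl group, a chlorine atom or an amine at this place would retain the activity of compound 2. Going by these compounds, it also stays open how large the true step is.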